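Swapping a ring oxygen for a methyl on the core

The source may report more compounds than this note shows. Statements on the series, on what has been measured and on what is new or still open speak of the compounds shown alone.

Measured compounds:
compound 1 `CS(=O)(=O)c1ccc(-n2nc(C(F)F)c(C#N)c2-c2cc(F)cc(F)c2)cc1` — "not determined" (no result reported) in a physicochemical assay for solubility; a lower number here means a less soluble compound, a higher number a more soluble compound
compound 2 `C[C@@H]1CN(c2c(C#N)c(C(F)(F)F)nn2-c2ccc(S(C)(=O)=O)cc2)[C@H](C)CO1` — "not determined" (no result reported) in this assay
compound 3 `C[C@@H]1CN(c2c(C#N)c(C(F)F)nn2-c2ccc(S(C)(=O)=O)cc2)[C@H](C)CO1` — 50 ug/mL

Going by the values given here, compound 3 is the only compound with a number in this assay: it gives 50 ug/mL. Compound 1 gives "not determined" (no result reported) and compound 2 gives "not determined" (no result reported), so nothing can be said of how they compare with it.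

Compound 4 `CC1CCCN(c2c(C#N)c(C(F)F)nn2-c2ccc(S(C)(=O)=O)cc2)C1` has not been measured yet. It differs from compound 3 in one place: a group of 7 heavy atoms (6 carbon, 1 nitrogen; one six-membered non-aromatic ring with 1 hetero atom) in place of a group of 8 heavy atoms (6 carbon, 1 nitrogen, 1 oxygen; one six-membered non-aromatic ring with 2 hetero atoms), on an aromatic carbon. The group that leaves contains a ring oxygen and two defined stereocentres; the group that enters, 3-methylpiperidin-1-yl, has neither.

No step between two measured compounds is shown, so the size of this change cannot be read from other pairs. The expectation is a step downward from compound 3 to compound 4 that goes somewhat beyond the scatter, estimated as a 2.5-fold lower number from compound 3 to compound 4 (0.40 log units; beyond the scatter). Compound 4 is therefore estimated at 20 ug/mL, with a range from 6 ug/mL to 60 ug/mL.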

Compound 4, solubility: 50 ug/mL
For compound 4 the middle estimate is 2.5-fold (0.40 log units) below the measured one; the range from low to high includes it.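

In this assay, replacing the ring-oxygen group with its two defined stereocentres by 3-methylpiperidin-1-yl, on this aromatic carbon of the shared core, gives no change at the digits printed from compound 3 to compound 4 (within the scatter). Going by these compounds alone, this single pair is the only readable comparison at this position, and it shows that here the ring oxygen and both defined stereocentres can be exchanged for this group without a change beyond the scatter. No measurement shown accounts for this outcome.

The compounds shown do not separate the part played by the ring oxygen from that of the methyl groups or the stereocentres, since all of these differ at once in this pair. As far as these compounds go, it also remains open whether a group of another kind at this position, such as a carboxylic acid or an open-chain amine, would shift the number.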